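The source may report more compounds than this note shows. Statements on the series, on what has been measured and on what is new or still open speak of the compounds shown alone.

Compound 1 `CC(=O)N1CCN(C(=O)[C@@H]2CC[C@@H](C)N2C(=O)C2=C(C(C)C)N3C(=N[C@@](C)(c4ccc(Cl)cc4)[C@H]3c3ccc(Cl)cc3)S2)CC1`: 79 ug/mL
Compound 2 `CC[C@@H]1CC[C@@H](C(=O)N2CCN(C(C)=O)CC2)N1C(=O)C1=C(C(C)C)N2C(=N[C@@](C)(c3ccc(Cl)cc3)[C@H]2c2ccc(Cl)cc2)S1`: 34 ug/mL

In a physicochemical assay for solubility, read by HPLC, in phosphate buffer, at pH 6.8 (a higher number here means a more soluble compound, a lower number a less soluble compound), compound 2 is the lower of the two at 34 ug/mL. Compound 3 `CC[C@@H]1CC[C@@H](C(=O)N2CCN(C)[C@H](C)C2)N1C(=O)C1=C(C(C)C)N2C(=N[C@@](C)(c3ccc(Cl)cc3)[C@H]2c2ccc(Cl)cc2)S1` differs from it as follows: 3,4-dimethylpiperazin-1-yl in place of 4-acetylpiperazin-1-yl on a carbonyl carbon. In words, this is 3,4-dimethylpiperazin-1-yl in place of 4-acetylpiperazin-1-yl on a carbonyl carbon. For the measured compounds named here, the only measured step, a 2.3-fold lower number from compound 1 to compound 2 (0.37 log units; beyond the scatter), involves a different change, so it offers only a rough guide to size. Going by the values given here, no measured compound tests this swap, and the direction rests on the structural change alone. The expected result is a modest rise or somewhat more: a 3.2-fold higher number from compound 2 to compound 3 (0.51 log units; beyond the scatter). For compound 3 the estimated value is 110 ug/mL, with an expected range of 35 ug/mL to 350 ug/mL.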

Compound 3, solubility: 14 ug/mL
For compound 3 the middle estimate is 7.9-fold (0.90 log units) above the measured one; measured number outside the range, below it.
By their numbers in this assay, from the lowest: compound 3; then compound 2; then compound 1.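

The group on a carbonyl carbon also moves the read-out in this assay: 3,4-dimethylpiperazin-1-yl in place of 4-acetylpiperazin-1-yl gives a 2.4-fold lower number from compound 2 to compound 3 (0.39 log units; beyond the scatter), so the direction here is downward for this swap. For the compounds shown here, compound 3 therefore stands lowest of the three compounds, and the earlier step on the saturated chain is no longer the only change that lowers the number. Nothing measured here gives a reason for this step.

Going by these compounds, the swap removes the acetyl and adds two methyl groups at once, so which of these carries the step stays open. A plain 4-methylpiperazin-1-yl or a morpholin-4-yl on this carbonyl carbon would help to separate them.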